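The source may hold more compounds than are shown below. What is called first, only, known or untested is meant among the compounds shown, and "the series" means these compounds.

Compound 1 `CC1(C)OC[C@@H](C/C=C\CCC(=O)O)[C@@H](c2cnccn2)O1`; compound 2 `CC1(C)OC[C@@H](C/C=C\CCC(=O)O)[C@@H](c2cncs2)O1`.

Of the compounds shown here, two have been measured in an assay on isolated protein for inhibition of Thromboxane-A synthase (Homo sapiens); on this read-out lower numbers stand for stronger inhibition and higher numbers for weaker inhibition. For compound 1 the result is only a limit, > 10000 nM. Compound 2 gives 80 nM. Going by the values given here, the single step between them is an at least 120-fold lower number from compound 1 to compound 2 (2.09 log units; beyond the scatter), brought about by 1,3-thiazol-5-yl in place of pyrazin-2-yl on a saturated ring carbon. Among the compounds with values here, compound 2 thus holds the only true number of the two results, while compound 1 sits at the limit of > 10000 nM in this assay, at which 1 of the 2 values shown sits.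

Compound 3 `CC1(C)OC[C@@H](C/C=C\CCC(=O)O)[C@@H](c2cnco2)O1` carries the change (1,3-oxazol-5-yl in place of 1,3-thiazol-5-yl on a saturated ring carbon). This is again an exchange of the small aromatic ring on the same carbon, but both rings here are five-membered with two hetero atoms, a narrower change than the measured one. That measured step shows how strongly this ring governs the result, so for compound 3 a moderately weaker outcome is expected, a 3.8-fold higher number from compound 2 to compound 3 (0.57 log units; beyond the scatter). Compound 3 is therefore estimated at 300 nM, with a likely range from 60 nM to 3000 nM.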

Compound 3, half-maximal inhibitory concentration: > 10000 nM
Compound 3: only a limit was reported; the forecaster's own chance of this, stated with the estimate: 10%; middle value at least 33-fold (1.52 log units) away from the limit.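

Exchanging only the sulfur of 1,3-thiazol-5-yl for the oxygen of 1,3-oxazol-5-yl gives an at least 120-fold higher number from compound 2 to compound 3 (2.09 log units; beyond the scatter). This carbon of the core therefore does more than separate a six-membered ring from a five-membered one: two five-membered aromatic rings with the same counts of heavy atoms, donors and acceptors, differing in a single atom, give very different results. Of the three groups shown, only 1,3-thiazol-5-yl gives a true number, and the other two compounds stop at a limit: the limit of > 10000 nM in this assay, at which 2 of the 3 values shown sit.

As far as these compounds go, the step from compound 1 to compound 3 cannot be read, and how far beyond the limit either compound lies stays open. Also open, from the compounds shown here alone, is whether a thiophene ring, with sulfur as its only hetero atom, or a phenyl ring on the same carbon would give a true number.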